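Bromine removal on a fused isatin core, a second instance

A few compounds are considered here, and "the series" means these few. Any claim that something is new, unique, unknown or untested is made for them only; others in the source may bear on it.

Measured compounds:
Compound 1 `O=C1C(=O)N(CN(c2ccccc2)c2ccccc2)c2ccccc21`: 33700 nM
Compound 2 `CN(C)CN1C(=O)C(=O)c2c(Br)cccc21`: 77900 nM
Compound 3 `O=C1C(=O)N(CN(c2ccccc2)c2ccccc2)c2cccc(Br)c21`: 98500 nM

Of the compounds shown here, three have been tested in an ADME assay on 184B5 cells (Homo sapiens) for cytotoxicity, read by sulforhodamine B assay, with a stated time of 48 h; on this read-out lower numbers stand for stronger inhibition of growth and higher numbers for weaker inhibition of growth. Compound 3 `O=C1C(=O)N(CN(c2ccccc2)c2ccccc2)c2cccc(Br)c21` carries a bromo group and gives 98500 nM, while compound 1 `O=C1C(=O)N(CN(c2ccccc2)c2ccccc2)c2ccccc21`, which lacks it, gives 33700 nM. The change between them, (hydrogen in place of bromo on an aromatic carbon), made a step of a 2.9-fold lower number from compound 3 to compound 1 (0.47 log units; beyond the scatter). Compound 2 `CN(C)CN1C(=O)C(=O)c2c(Br)cccc21`, measured at 77900 nM, stands close to compound 3 on this read-out and differs from it in the side chain on the nitrogen; the difference between the two cores is not broken down here.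

Compound 4 `CN(C)CN1C(=O)C(=O)c2ccccc21` has not yet been measured in this assay. It is related to compound 2 by hydrogen in place of bromo on an aromatic carbon, the same change that links compound 3 to compound 1. Since the earlier instance moved the number by a 2.9-fold lower number from compound 3 to compound 1 (0.47 log units; beyond the scatter), the step from compound 2 is expected to be of similar size, about a 2.7-fold lower number from compound 2 to compound 4 (0.43 log units; beyond the scatter). On that basis compound 4 is estimated at 29000 nM, with the likely range running from 13000 nM to 65000 nM.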

Compound 4, concentration for 50% growth inhibition: 73700 nM
Compound 4: the middle estimate sits 2.5-fold (0.41 log units) below what was measured, outside the stated range (above it).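

In this assay, hydrogen in place of bromo on an aromatic carbon gave a 1.1-fold lower number from compound 2 to compound 4 (0.02 log units; within the scatter), so compound 2 and compound 4 cannot be told apart on this read-out. The change therefore did not carry over in size from one core to the other: the same change on two cores in this assay, a 2.9-fold lower number (0.47 log units; beyond the scatter) from compound 3 to compound 1 and a 1.1-fold lower number (0.02 log units; within the scatter) from compound 2 to compound 4, 2.8-fold (0.44 log units) apart, beyond the scatter of two such steps. This shows that a step read on one core of this series cannot simply be transferred to the other, but two instances do not show what in the two side chains on the nitrogen sets them apart, nor how the change would behave on any further core.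

The compounds shown leave open whether a chloro or methoxy group on the same aromatic carbon would follow the pattern of bromo on each core. They also leave open how the change would behave with a side chain on the nitrogen carrying a morpholine or a carboxylic acid.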